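The source may hold more compounds than are shown below. What is called first, only, known or untested is meant among the compounds shown, and "the series" means these compounds.

In a functional assay on ECV-304 cells (Homo sapiens) for cytotoxicity (a lower number here means a stronger inhibitor, a higher number a weaker inhibitor), compound 1 (`Cc1ccc(S(=O)(=O)NN2C(=S)S/C(=C\c3ccc(Cl)c(Cl)c3)C2O)cc1`) gives > 50000 nM as a limit of the assay, not a number. Compound 2 (`O=C1/C(=C/c2ccc(Cl)c(Cl)c2)SC(=S)N1NS(=O)(=O)c1cccs1`) gives > 50000 nM and this is also a limit. Compound 3 (`COc1cccc(/C=C2\SC(=S)N(NS(=O)(=O)c3ccccc3)C2=O)c1`) reads > 50000 nM and this too is only a limit. Compound 3 therefore stands at the limit of > 50000 nM in this assay, at which 3 of the 3 values shown sit, and has no exact value.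

Compound 4 (`O=C1/C(=C/c2ccc(Cl)c(Cl)c2)SC(=S)N1NS(=O)(=O)c1ccccc1`) differs from compound 3 in one place: 3,4-dichlorophenyl in place of 3-methoxyphenyl on a double-bonded chain carbon bound to a double-bonded ring carbon and the rest is unchanged. Compound 2 carries the same 3,4-dichlorophenyl and shows the limit > 50000 nM in this assay so no step in either direction beyond the usual scatter is expected. The expected move is a number no higher from compound 3 to compound 4 (the limit leaves the size open) and no more. For compound 4 the estimate is 50000 nM with an expected range from 20000 nM to 100000 nM in this assay.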

Compound 4, half-maximal inhibitory concentration: > 50000 nM
Compound 4: only a limit was reported; the forecaster's own chance of this, stated with the estimate: 80%; the middle value lies on the limit itself.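

Going by these compounds alone, compound 4 gives only a limit, as do compound 2 and compound 3, so no step to compound 4 can be read in this assay. The compounds shown leave open what exact value any of them has: the limit of > 50000 nM in this assay, at which 4 of the 4 values shown sit.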